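This account rests on a few compounds, and the source may have more. Where it says the series, first, only, none or still open, it means among the compounds named here.

Measured so far in an in vitro ADME assay on microsomes from liver (Rattus norvegicus) for metabolic stability; on this read-out lower numbers stand for a shorter-lived compound and higher numbers for a longer-lived compound:
- compound 1 `CNc1nc(NCc2ccc(NC(=O)c3ccc(C#N)cc3)cc2)c2ccccc2n1`: 0.167 h
- compound 2 `CNc1nc(NCc2ccc(NC(=O)c3ccc(C)cc3)cc2)c2ccccc2n1`: 0.267 h
- compound 3 `Cc1ccc2c(NCc3ccc(NC(=O)c4ccc(F)cc4)cc3)nc(N3CCC3)nc2c1`: 0.117 h

Compound 3, at 0.117 h, lies within the scatter of compound 1 and beyond the scatter under compound 2. Compound 4 `Cc1ccc2c(NCc3ccc(NC(=O)c4ccc(F)cc4)cc3)nc(N3CCN[C@H](C)C3)nc2c1` has 3-methylpiperazin-1-yl in place of azetidin-1-yl, on an aromatic carbon between two ring nitrogen atoms: 3-methylpiperazin-1-yl in place of azetidin-1-yl on an aromatic carbon.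

For the measured compounds named here, the only measured step, a 1.6-fold higher number from compound 1 to compound 2 (0.20 log units; within the scatter), concerns a different group and stays within the scatter. Going by the values given here, no measured pair tests this exchange, so no step beyond the scatter is expected in this assay. The expected step is a 1.3-fold higher number from compound 3 to compound 4 (0.11 log units; within the scatter). For compound 4 the estimate is 0.15 h, with an expected range from 0.07 h to 0.35 h.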

Compound 4, half-life: 0.0667 h
Compound 4: middle estimate off by 2.2-fold (0.35 log units), on the high side; the whole stated range lies above it.
By their numbers in this assay, from the lowest: compounds 4, 3, 1 and 2 (each within the scatter of the next, the first and the last beyond it).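

Placing 3-methylpiperazin-1-yl instead of azetidin-1-yl on the aromatic carbon between two ring nitrogen atoms gives a 1.8-fold lower number from compound 3 to compound 4 (0.24 log units; within the scatter) in this assay. At this position, then, a six-membered ring with two nitrogens and a four-membered ring with one do not differ beyond the scatter, at least in this single pair. Nothing available explains the result.

Going by these compounds, it remains open whether the methyl or the second ring nitrogen matters more here. A plain piperazine or a morpholine at this position would help separate the two.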